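This account rests on a few compounds, and the source may have more. Where it says the series, first, only, none or still open, it means among the compounds named here.

Measured in a functional assay on A549 cells (Homo sapiens) for cytotoxicity, read by MTT assay, with a stated time of 48 h (on this read-out higher numbers stand for weaker inhibition and lower numbers for stronger inhibition), so far:
Compound 1 `CCOC(=O)[C@@]1(C(=O)Nc2ccccc2)C[C@@H]1c1cc(OC)c(OC)c(OC)c1` gives > 100000 nM which is a limit of the assay.
Compound 2 `CCOC(=O)[C@]1(C(=O)Nc2ccccc2)C[C@@H]1c1cc(OC)c(OC)c(OC)c1` gives 21300 nM as a measured number.
Compound 3 `CCOC(=O)[C@@]1(C(=O)Nc2ccccc2Cl)C[C@@H]1c1cc(OC)c(OC)c(OC)c1` gives 29000 nM as a measured number.

Compound 3 at 29000 nM stands level with compound 2 at 21300 nM within the scatter. Compound 4 `CCOC(=O)[C@]1(C(=O)Nc2ccccc2Cl)C[C@@H]1c1cc(OC)c(OC)c(OC)c1` follows from compound 3 by the two compounds have the same atoms and bonds and differ only in configuration as drawn: 1 of 2 stereo elements differ; a stereocentre at a saturated ring carbon is drawn S in compound 3 and R in compound 4 and the atoms and bonds stay the same.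

The closest measured precedent is an at least 4.6-fold lower number from compound 1 to compound 2 (0.67 log units; beyond the scatter) and it is the same kind of change from S to R at a saturated ring carbon, made without the chloro. That step is a bound and not an exact size, given the limit of > 100000 nM in this assay, at which 1 of the 3 values shown sits, as its reference. Among the measured compounds shown here, it also rests on the fact that compounds 1 and 2 differ only in the configuration as drawn as the only difference in that pair. The other measured step, an at least 3.4-fold lower number from compound 1 to compound 3 (0.53 log units; beyond the scatter) for chloro in place of hydrogen on an aromatic carbon, shows that the chloro already moves the S form. How much of the stereocentre step survives with the chloro present is therefore open.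

The estimated step is a 4.1-fold lower number from compound 3 to compound 4 (0.62 log units; beyond the scatter) toward a lower number in this assay as the expected direction. The expected value for compound 4 is 7000 nM with an estimated range from 1500 nM to 30000 nM for now.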

Compound 4, half-maximal inhibitory concentration: 50900 nM
Estimate against measurement, compound 4: 7.3-fold (0.86 log units) below; the whole stated range lies below it.
By their numbers in this assay, from the lowest: compounds 2, 3 and 4 (each within the scatter of the next, the first and the last beyond it). At a limit, above all of these: compound 1.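

In this assay, the change from S to R at the saturated ring carbon gave an at least 4.6-fold lower number from compound 1 to compound 2 (0.67 log units; beyond the scatter) without the chloro, but this separation does not carry over to the chlorinated pair, where a 1.8-fold higher number from compound 3 to compound 4 (0.24 log units; within the scatter) stays within the scatter. Chloro in place of hydrogen on an aromatic carbon also depends on the configuration at that carbon, with a 2.4-fold higher number from compound 2 to compound 4 (0.38 log units; beyond the scatter) in the R form running opposite to the step seen in the S form: the same change on two cores in this assay, an at least 3.4-fold lower number (0.53 log units; beyond the scatter) from compound 1 to compound 3 and a 2.4-fold higher number (0.38 log units; beyond the scatter) from compound 2 to compound 4, at least 8.2-fold (0.91 log units) apart, beyond the scatter of two such steps The gap between those two steps is a bound and not an exact size, since compound 1 stands at a limit: the limit of > 100000 nM in this assay, at which 1 of the 4 values shown sits.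

The compounds shown leave open whether this dependence on configuration is particular to chloro or would also appear with a fluoro or a methyl group on the same aromatic carbon. Also open, as far as these compounds go, are the effect of a carboxylic acid in place of the ethyl ester and the effect of changing the second stereocentre, which is drawn the same in all four compounds.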